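Replacing pyridin-2-yl with 4-methoxyphenyl: expected inhibition

A few compounds are considered here, and "the series" means these few. Any claim that something is new, unique, unknown or untested is made for them only; others in the source may bear on it.

In an assay on CHO cells for displacement of a labelled ligand from adenosine receptor A1 (Homo sapiens), read by scintillation counting, tested at 10 uM (on this read-out lower numbers stand for less inhibition and higher numbers for more inhibition at the one concentration tested (going by the name of the read-out)), compound 2 `CC(C)(C)Cc1c(-c2ccccn2)sc(N)c1C(=O)c1ccc(Cl)cc1` gives 1%. Compound 1 `Cc1csc(N)c1C(=O)c1ccc(Cl)cc1` gives 1% in this assay, and compound 3 `CC(C)(C)Cc1csc(N)c1C(=O)c1ccc(Cl)c(Cl)c1` gives 1% in this assay; compound 2 stands level with both at the digits shown, within the scatter. Among the measured compounds shown here, no pair of measured compounds differs in one place only, so the series offers no measured step to lean on. Compound 4 `COc1ccc(-c2sc(N)c(C(=O)c3ccc(Cl)cc3)c2CC(C)(C)C)cc1` is compound 2 with 4-methoxyphenyl in place of pyridin-2-yl on an aromatic carbon. The step of a number 2 percentage points higher from compound 2 to compound 4 (within the scatter) is expected to stay within the scatter, because compound 2 gives 1% and compounds 1 and 3 sit at the same level with different groups on the shared core. Compound 4 is therefore estimated at 3%, within 0% to 15%.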

Compound 4, a percentage reported as inhibition, at one concentration (the size of the read-out at that concentration, not a potency): 1%
Estimate against measurement, compound 4: 2 percentage points above, and the stated range covers the measured number.
By their numbers in this assay, from the lowest: compounds 1, 2, 3 and 4 (each within the scatter of the next).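

At this aromatic carbon next to the ring sulfur, 4-methoxyphenyl in place of pyridin-2-yl gives no change at the digits printed from compound 2 to compound 4 (within the scatter) in this assay. Among the compounds shown here, this is the first one-place comparison, and exchanging the ring with a hetero atom for a ring of carbon only leaves the read-out without a visible response. Nothing at hand accounts for this flat result.

From the compounds shown here alone, whether a carboxylic acid or an aminomethyl group on this carbon would give inhibition beyond the scatter stays open. Equally open, going by these compounds, is whether changing the neopentyl group or the amino group would do so.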